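Adding a chloro group to compound 3

This account rests on a few compounds, and the source may have more. Where it says the series, first, only, none or still open, it means among the compounds named here.

Compound 1 `O=C(Cn1nc(-c2ccccc2)c2ccccc2c1=O)Nc1ccccc1` is the reference point in a functional assay on HepG2 cells (Homo sapiens) for antiproliferative activity, read by sulforhodamine B assay, with a stated time of 72 h (a higher number here means a weaker inhibitor, a lower number a stronger inhibitor), where it gives 13400 nM. Compound 3 `O=C(Cn1nc(Cc2ccccc2)c2ccccc2c1=O)Nc1ccccc1` gives 66000 nM in this assay, and swapping phenyl for benzyl on an aromatic carbon accounts for a 4.9-fold higher number from compound 1 to compound 3 (0.69 log units; beyond the scatter). Compound 2 `O=C(Cn1nc(-c2ccccc2)c2ccccc2c1=O)Nc1ccccc1Cl` gives 33000 nM, which lies within the usual scatter of compound 3, so those two values cannot be ranked. Both stand apart from compound 1.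

Compound 4 `O=C(Cn1nc(Cc2ccccc2)c2ccccc2c1=O)Nc1cccc(Cl)c1` changes compound 3 in a single place: chloro in place of hydrogen on an aromatic carbon. This is chloro in place of hydrogen on an aromatic carbon, meta to a large group, turning phenyl into 3-chlorophenyl.

Only compound 2 offers a measured precedent for this change, with a 2.5-fold higher number from compound 1 to compound 2 (0.39 log units; beyond the scatter). That modest step came from a different parent, compound 1, and compound 2 does not carry its chloro meta to a large group. This single example hints at a slightly higher number but cannot fix the direction, so only a small shift is expected, possibly none beyond the scatter. The expected change is a 1.2-fold higher number from compound 3 to compound 4 (0.08 log units; within the scatter). For compound 4 the estimated value is 80000 nM, with an expected range from 30000 nM to 200000 nM.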

Compound 4, half-maximal inhibitory concentration: 14300 nM
Compound 4: the middle estimate sits 5.6-fold (0.75 log units) above what was measured, outside the stated range (below it).
By their numbers in this assay, from the lowest: compounds 1 and 4 (each within the scatter of the next); then compounds 2 and 3 (each within the scatter of the next).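

In this assay, chloro in place of hydrogen on an aromatic carbon, meta to a large group, gives a 4.6-fold lower number from compound 3 to compound 4 (0.66 log units; beyond the scatter), so turning anilino into (3-chlorophenyl)amino can produce a stronger inhibitor, something compound 2 gave no sign of. This change therefore has no single direction across the compounds shown, and the one earlier example could not serve as a general guide to what a chloro does here: the same change on two cores in this assay, a 2.5-fold higher number (0.39 log units; beyond the scatter) from compound 1 to compound 2 and a 4.6-fold lower number (0.66 log units; beyond the scatter) from compound 3 to compound 4, 11-fold (1.06 log units) apart, beyond the scatter of two such steps The two steps differ in more than their direction, since their parents carry phenyl or benzyl on the shared core and compound 2 does not carry its chloro meta to a large group, so either difference could lie behind the reversal.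

The compounds shown leave open which of these two differences matters, a question that a phenyl compound with its chloro meta to a large group would help to settle. They also leave open whether the lower number is particular to chloro or would also appear with another group in the same place, such as a methoxy group, an amine or a carboxylic acid.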